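The source may hold more compounds than are shown below. What is called first, only, known or untested is meant among the compounds shown, and "the series" means these compounds.

Measured in an ADME assay on SH-SY5Y cells (Homo sapiens) for cytotoxicity, read by MTT assay, with a stated time of 48 h; a lower number here means that less compound is needed, a higher number that more compound is needed for the effect:
Compound 1 `O=C(O)c1ccccc1-c1ccccc1C(=O)NCCCCCCCn1cc(-c2cccnc2)nn1`: > 500 nM, a limit and not a number
Compound 2 `NC(=O)c1ccccc1-c1ccccc1C(=O)NCCCCCCCn1cc(-c2cccnc2)nn1`: 289 nM
Compound 3 `O=C(O)c1ccc(-c2ccccc2C(=O)NCCCCCCCn2cc(-c3cccnc3)nn2)cc1`: 224 nM

Going by the values given here, only one other number stands near the last entry, giving a 1.3-fold lower number from compound 2 to compound 3 (0.11 log units; within the scatter). Compound 4 `O=C(NCCCCCCCn1cc(-c2cccnc2)nn1)c1ccccc1-c1cccnc1` has pyridin-3-yl in place of 4-carboxyphenyl on an aromatic carbon, ortho to a large group (pyridin-3-yl in place of 4-carboxyphenyl on an aromatic carbon). Among the compounds with values here, no measured step makes this exchange. The closest evidence is exchanges of the group at this place, with an at least 2.2-fold lower number from compound 1 to compound 3 (0.34 log units; beyond the scatter) and the change on the carbonyl carbon, with an at least 1.7-fold lower number from compound 1 to compound 2 (0.23 log units; that floor lies within the scatter). Both rest on a limit, so their true sizes are open. A modest move toward a lower number is expected, estimated as a 1.9-fold lower number from compound 3 to compound 4 (0.27 log units; within the scatter), though no change beyond the scatter remains possible. The expected value for compound 4 is 120 nM, with an estimated range of 20 nM to 450 nM.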

Compound 4, half-maximal effective concentration: 36.5 nM
Estimate against measurement, compound 4: 3.3-fold (0.52 log units) above; the measured number falls inside the stated range.
By their numbers in this assay, from the lowest: compound 4; then compounds 3 and 2 (each within the scatter of the next). At a limit, above all of these: compound 1.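

In this assay, the carboxyphenyl and carbamoylphenyl groups on this aromatic carbon left compound 2 and compound 3 within the scatter of each other, whereas pyridin-3-yl separates clearly from both: a 6.1-fold lower number from compound 3 to compound 4 (0.79 log units; beyond the scatter) and a 7.9-fold lower number from compound 2 to compound 4 (0.90 log units; beyond the scatter). The step against compound 1 is larger, an at least 13-fold lower number from compound 1 to compound 4 (1.13 log units; beyond the scatter). Compound 1 is held at a limit, so that step is only a floor: the limit of > 500 nM in this assay, at which 1 of the 4 values shown sits.

Going by these compounds, it remains open whether the shift follows the ring nitrogen or the loss of the carbonyl substituent, which an unsubstituted phenyl or a pyridin-4-yl group at this place would separate. On these data alone, the effect of a shorter or longer chain on this pyridin-3-yl compound also remains open.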